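Working notes on a pyridyl exchange in the series

A few compounds are considered here, and "the series" means these few. Any claim that something is new, unique, unknown or untested is made for them only; others in the source may bear on it.

For the measured compounds named here, compound 2 `Fc1cnc(Nc2cc3[nH]c(-c4cccc(C(F)(F)F)c4)nc3cn2)c(F)c1` is set against the one other measured member, compound 1 `COc1cccc(Nc2cc3[nH]c(-c4cccc(C(F)(F)F)c4)nc3cn2)n1`. In an ADME assay on microsomes from liver (Homo sapiens) for metabolic stability, read by LC-MS, with a stated time of 30 min, tested at 0.1 uM (a lower number here means that less of the compound is left, a higher number that more of the compound is left), compound 1 gives 45%, and in this assay compound 2 gives 32%, the lower of the two numbers in hand. Going by the values given here, the only measured step, a number 13 percentage points lower from compound 1 to compound 2 (beyond the scatter), arises from exchanging the group on the same nitrogen that is altered here.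

Compound 3 `N#Cc1ccc(Nc2cc3[nH]c(-c4cccc(C(F)(F)F)c4)nc3cn2)nc1` is not yet measured. It differs from compound 2 by 5-cyanopyridin-2-yl in place of 3,5-difluoropyridin-2-yl on a nitrogen on an aromatic ring. Among the compounds with values here, the single step that bears on this change is the earlier exchange on that nitrogen, and it moved the read-out by a modest amount. Within the data shown here, no measured step covers the 5-cyanopyridin-2-yl group itself, so the direction of its effect is open. A step of similar or smaller size than the one seen is expected, without a firm direction. Compound 3 is therefore expected to give about 38% in this assay, within a range from 18% to 60%. The step implied by this estimate, a number 6 percentage points higher from compound 2 to compound 3 (within the scatter), is expected to remain within the scatter of this assay.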

Compound 3, percent of the compound remaining: 39%
Estimate against measurement, compound 3: 1 percentage points below; the measured number falls inside the stated range.
By their numbers in this assay, from the lowest: compounds 2, 3 and 1 (each within the scatter of the next, the first and the last beyond it).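

In this assay, the nitrile-bearing 5-cyanopyridin-2-yl group gives a number 7 percentage points higher from compound 2 to compound 3 (within the scatter), and it gives a number 6 percentage points lower from compound 1 to compound 3 (within the scatter). This group therefore cannot be told apart from either 3,5-difluoropyridin-2-yl or 6-methoxypyridin-2-yl on this nitrogen, even though those two groups remain separated by the earlier step, a number 13 percentage points lower from compound 1 to compound 2 (beyond the scatter), so the one difference beyond the scatter at this position now has a group that sits within the scatter of both ends. Nothing in hand accounts for any of these steps.

As far as these compounds go, all three compounds carry a substituted pyridin-2-yl group on this nitrogen, so the effect of a saturated amine such as morpholine, a longer alkyl chain, or a pyridin-2-yl group bearing a carboxylic acid remains open. Also open, from the compounds shown here alone, is how the read-out responds to a change away from this nitrogen, such as a methyl group in place of the trifluoromethyl group on the shared core.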